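This account rests on a few compounds, and the source may have more. Where it says the series, first, only, none or still open, it means among the compounds named here.

Three measured compounds frame the series. Compound 1, `COc1cc2cc(C=C3CC[N+](C)(Cc4ccccc4)CC3)sc2cc1OC`, gives 1000 ug/mL in a physicochemical assay for solubility; a lower number here means a less soluble compound, a higher number a more soluble compound. Compound 2, `COc1cc2cc(C(=O)CCC3CC[N+](C)(Cc4ccc([N+](=O)[O-])o4)CC3)sc2cc1OC`, gives 600 ug/mL in this assay. Compound 3, `COc1cc2cc(C(=O)CCc3cc[n+](C)cc3)sc2cc1OC`, gives 3000 ug/mL in this assay and stands highest of the three numbers; its distance to compound 1 and to compound 2 lies beyond the scatter in both cases, so compound 3 is the most soluble of the measured set. For the measured compounds named here, no pair of measured compounds differs in a single place, so no step size for any one change is known from the data.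

Compound 4, `CCOCC[n+]1ccc(CCC(=O)c2cc3cc(OC)c(OC)cc3s2)cc1`, is the next entry: ethoxymethyl in place of hydrogen on a saturated chain carbon bound to an aromatic nitrogen. Going by the values given here, no measured pair shows what this change does to solubility. The expectation is a small downward step, a 1.5-fold lower number from compound 3 to compound 4 (0.18 log units; within the scatter), for compound 4 against compound 3, with a real chance that it falls within the scatter. Compound 4 is estimated at 2000 ug/mL in this assay, between 800 ug/mL and 4500 ug/mL, because compound 3 gives 3000 ug/mL and a single chain enlargement rarely moves such a value far.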

Compound 4, solubility: 50000 ug/mL
Estimate against measurement, compound 4: 25-fold (1.40 log units) below; the measured number lies above the stated range.
By their numbers in this assay, from the lowest: compounds 2 and 1 (each within the scatter of the next); then compound 3; then compound 4.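

For the compounds shown here, on the saturated chain carbon bound to an aromatic nitrogen, ethoxymethyl in place of hydrogen gives a 17-fold higher number from compound 3 to compound 4 (1.22 log units; beyond the scatter) in this assay, the first single-place step and a large one. The same difference reads methyl to 2-ethoxyethyl, so the group on this nitrogen is now shown to be a place where one change can move the number far beyond the scatter. Nothing shown bears on why the number moves this far.

A single step cannot separate the ether oxygen from the added chain length: an n-butyl or a 2-hydroxyethyl group at the same place would be needed to tell them apart. Also open, on these data alone, is whether a change at the charged nitrogen of compound 2, which stands at 600 ug/mL, gives a step of like size.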